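Chloro to nitro step from compound 3 to compound 4

A few compounds are considered here, and "the series" means these few. Any claim that something is new, unique, unknown or untested is made for them only; others in the source may bear on it.

Measured so far in a functional assay on HCT-116 cells (Homo sapiens) for inhibition, read by MTT assay, with a stated time of 72 h; a higher number here means a weaker inhibitor, a lower number a stronger inhibitor:
compound 1 `O=C1Nc2cc(Cl)ccc2/C1=N/NC(=S)N1CCN(c2ccccc2)CC1`: 17900 nM
compound 2 `Cc1ccccc1N1CCN(C(=S)N/N=C2\C(=O)Nc3ccc(Cl)cc32)CC1`: 4910 nM
compound 3 `O=C1Nc2ccc(Cl)cc2/C1=N/NC(=S)N1CCN(c2ccccc2Cl)CC1`: 4910 nM

Compound 3 sits level with compound 2 at the digits shown, the two together giving the lowest numbers of the three; compound 1 gives a higher number, beyond the scatter, but it differs from compound 3 in more than one place, so no single step can be drawn from it. For the measured compounds named here, the only single-point step recorded is no change at the digits printed from compound 2 to compound 3 (within the scatter): swapping methyl for chloro on the aromatic carbon left this assay unmoved.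

Compound 4 `O=C1Nc2ccc(Cl)cc2/C1=N/NC(=S)N1CCN(c2ccccc2[N+](=O)[O-])CC1` carries the change (nitro in place of chloro on an aromatic carbon). Going by the values given here, this step has not been measured; the one step that bears on it, from compound 2 to compound 3, touched the same aromatic carbon and stayed within the scatter. On that basis no move beyond the scatter is expected in this assay, with an estimated step of a 1.1-fold higher number from compound 3 to compound 4 (0.05 log units; within the scatter). Compound 4 is therefore expected to give 5500 nM, in the range 2500 nM to 12000 nM.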

Compound 4, half-maximal inhibitory concentration: 4570 nM
Compound 4: the middle estimate sits 1.2-fold (0.08 log units) above what was measured; the measured number falls inside the stated range.
By their numbers in this assay, from the lowest: compounds 4, 2 and 3 (each within the scatter of the next); then compound 1.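

In this assay, nitro in place of chloro on this aromatic carbon, ortho to a large group, gives a 1.1-fold lower number from compound 3 to compound 4 (0.03 log units; within the scatter), and nitro in place of methyl gives a 1.1-fold lower number from compound 2 to compound 4 (0.03 log units; within the scatter). Together with the earlier step, no change at the digits printed from compound 2 to compound 3 (within the scatter), this places methyl, chloro and nitro within the scatter of one another, so the flat reading now extends to a group that brings hydrogen-bond acceptors, where chloro and methyl bring none. No supporting data are available to explain this flat response.

On these data alone, whether the position stays flat for an amine, a carboxylic acid or a longer chain remains open. Also open, as far as these compounds go, is whether the same three groups would read alike on another carbon of this ring, and compound 1 differs from these compounds in more than one place, so it cannot settle that.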